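The source may hold more compounds than are shown below. What is called first, only, known or untested is meant among the compounds shown, and "the series" means these compounds.

Three members of this series have been measured in a functional assay on COLO 205 cells (Homo sapiens) for inhibition, read by sulforhodamine B assay, with a stated time of 48 h, tested at 50 uM; a lower number here means less inhibition of growth, a higher number more inhibition of growth at the concentration tested. Compound 1 `COc1ccccc1/C=C/C(=O)/C=C/c1ccc(OCc2cn(CCOc3cc(=O)oc4ccccc34)nn2)c(OC)c1` gives 67%, compound 3 `COc1ccccc1/C=C/C(=O)/C=C/c1ccc(OCc2cn(CCCCOc3cc(=O)oc4ccccc34)nn2)c(OC)c1` gives 47%, and compound 2 `COc1ccc(/C=C/C(=O)/C=C/c2ccc(OCc3cn(CCCCCOc4cc(=O)oc5ccccc45)nn3)c(OC)c2)cc1` gives 30%. Compound 2 thus stands lowest of the three numbers, with compound 3 nearest and compound 1 furthest, both gaps beyond the scatter. Compound 4 `COc1cc(/C=C/C(=O)/C=C/c2cc(OC)c(OC)c(OC)c2)ccc1OCc1cn(CCCCCOc2cc(=O)oc3ccccc23)nn1` is not yet measured; it differs from compound 2 by 3,4,5-trimethoxyphenyl in place of 4-methoxyphenyl on a double-bonded chain carbon bound to a double-bonded chain carbon. Within the data shown here, no step between measured compounds bears on this change, so the expectation rests on the starting value alone: a moderate rise in this assay is expected, a number 12 percentage points higher from compound 2 to compound 4 (beyond the scatter), though a move within the scatter cannot be excluded. Compound 4 is estimated at 42%, in the range 22% to 62%.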

Compound 4, percent growth inhibition at one concentration: 51%
Estimate against measurement, compound 4: 9 percentage points below, and the stated range covers the measured number.
By their numbers in this assay, from the lowest: compound 2; then compounds 3 and 4 (each within the scatter of the next); then compound 1.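

In this assay, replacing 4-methoxyphenyl with 3,4,5-trimethoxyphenyl on a double-bonded chain carbon bound to a double-bonded chain carbon gives a number 21 percentage points higher from compound 2 to compound 4 (beyond the scatter). Among these compounds, this is the first single-place comparison, and it shows that the number responds to a change at this position, rising with this replacement. No evidence on the cause of the rise is available.

Going by these compounds, whether the same replacement gives a rise with a shorter linking chain remains open. So does the reading for a carboxylic acid or a dimethylamino group on this ring.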